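Chloro to Amino Exchange on the Core of Compound 3

The compounds below may be only part of what the source reports. "The series", "measured", "known", "first", "only" and "open" are said of these compounds alone.

Measured compounds:
compound 1, `Nc1nc(=O)n(COCCO)cc1[N+](=O)[O-]`, 71 ug/mL
compound 2, `CC(=O)OCCOCn1cnc2c(Cl)nc(Cl)nc21`, 12 ug/mL
compound 3, `Nc1nc2c(nc(Cl)n2COCCO)c(=O)[nH]1`, 350 ug/mL

In a functional assay on L1210 cells (Mus musculus) for inhibition (a lower number here means a stronger inhibitor, a higher number a weaker inhibitor), compound 3 gives 350 ug/mL, the highest of the three numbers. Compound 1 gives 71 ug/mL and compound 2 gives 12 ug/mL, both beyond the scatter from compound 3, so compound 3 is the weakest inhibitor of the three. Among the compounds with values here, no pair of measured compounds differs in a single place, so no measured step guides the next change.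

Compound 4, `Nc1nc2c(nc(N)n2COCCO)c(=O)[nH]1`, differs from compound 3 by amino in place of chloro on an aromatic carbon. Within the data shown here, with no precedent among the measured compounds for this exchange, the expected step is a 1.2-fold lower number from compound 3 to compound 4 (0.07 log units; within the scatter), no direction favoured beyond the scatter. Compound 4 is estimated at 300 ug/mL, in the range 100 ug/mL to 1000 ug/mL.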

Compound 4, concentration for 50% inhibition: > 500 ug/mL
Compound 4: only a limit was reported; the forecaster's own chance of this, stated with the estimate: 20%; middle value at least 1.6-fold (0.22 log units) from the limit.
By their numbers in this assay, from the lowest: compound 2; then compound 1; then compound 3. At a limit, above all of these: compound 4.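

In this assay compound 4 gives > 500 ug/mL as a limit, not a number. Amino in place of chloro on this aromatic carbon, between two ring nitrogen atoms, gives the series its first single-place step, an at least 1.4-fold higher number from compound 3 to compound 4 (0.15 log units; that floor lies within the scatter) and so shows no sign of stronger inhibition with amino at this position. Going by these compounds, whether bromo, methyl or methoxy on the same carbon would give a lower number than compound 3 remains open. The true size of the step also remains open, with only a floor to read: the limit of > 500 ug/mL in this assay, at which 1 of the 4 values shown sits.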